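Aryl swap on the saturated ring carbon of the acetyl core

The source may report more compounds than this note shows. Statements on the series, on what has been measured and on what is new or still open speak of the compounds shown alone.

compound 1, `COc1cc(C2=NN(C(C)=O)C(c3cc(Cl)cc(Cl)c3)O2)cc(OC)c1OC` — 52.7%
compound 2, `COc1cc(C2=NN(C(C)=O)C(c3cc(OC)c(OC)c(OC)c3)O2)cc(OC)c1OC` — -1.8%

In a functional assay on PC-3 cells (Homo sapiens) for antiproliferative activity, read by MTT assay, tested at 1 uM (a higher number here means a stronger effect of the compound at the concentration tested, a lower number a weaker effect), compound 1 gives 52.7%, the highest of the two numbers. Compound 2 gives -1.8%, a gap beyond the usual scatter. Among the compounds with values here, no two measured compounds differ in a single place, so no step size is known from the data.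

Compound 3, `COc1cc(C2=NN(C(C)=O)C(c3ccccc3C(F)(F)F)O2)cc(OC)c1OC`, differs from compound 1 by 2-(trifluoromethyl)phenyl in place of 3,5-dichlorophenyl on a saturated ring carbon. Within the data shown here, the one comparison available shows the phenyl carrying chlorine outscoring the phenyl carrying methoxy groups, and compound 3 again carries a halogenated phenyl, though its substitution pattern is untested here. The step from compound 1 to compound 3 is expected to be a moderate decrease, a number 17.7 percentage points lower from compound 1 to compound 3 (beyond the scatter), which may not exceed the scatter. Compound 3 is estimated at 35%, with a range from 5% to 60%.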

Compound 3, a percentage reported as inhibition, at one concentration (the size of the read-out at that concentration, not a potency): -11%
Beside the measured number, compound 3's estimate is 46 percentage points above it; measured number outside the range, below it.
By their numbers in this assay, from the lowest: compounds 3 and 2 (each within the scatter of the next); then compound 1.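

In this assay, 2-(trifluoromethyl)phenyl in place of 3,5-dichlorophenyl on the saturated ring carbon gives a number 63.7 percentage points lower from compound 1 to compound 3 (beyond the scatter), so a halogen-bearing phenyl at this position does not by itself keep the effect. Compound 3 and compound 2 lie within the scatter of each other, which leaves compound 1 as the only one of the three that stands clear of the rest. Nothing available here accounts for the loss.

This swap replaces both the substituent and its place on the phenyl, so the contribution of each cannot be separated from these compounds. Also open, from the compounds shown here alone, is how a plain phenyl or a bromophenyl on the same carbon would compare with the 3,5-dichlorophenyl of compound 1.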